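This account rests on a few compounds, and the source may have more. Where it says the series, first, only, none or still open, it means among the compounds named here.

Going by the values given here, in a functional assay on MCF7 cells (Homo sapiens) for inhibition, read by MTT assay, with a stated time of 72 h (a higher number here means a weaker inhibitor, a lower number a stronger inhibitor), compound 1 `Cc1ccc(-n2c(-c3coc4cc(C)c(Cl)cc4c3=O)nc(-c3ccccc3)c2-c2ccccc2)c(C)c1` gives 6250 nM, the higher of the two numbers so far, and compound 2 `Cc1cc2occ(-c3nc(-c4ccccc4)c(-c4ccccc4)n3-c3ccc(Br)cc3)c(=O)c2cc1Cl` gives 1560 nM. Compound 3 `Cc1ccc(-n2c(-c3coc4cc(C)c(Cl)cc4c3=O)nc(-c3ccccc3)c2-c2ccccc2)cc1` has hydrogen in place of methyl on an aromatic carbon, turning 2,4-dimethylphenyl into 4-methylphenyl (hydrogen in place of methyl on an aromatic carbon). Among the compounds with values here, only one measured step bears on this: a 4.0-fold lower number from compound 1 to compound 2 (0.60 log units; beyond the scatter). That step also loses this methyl, but it exchanges the remaining methyl for bromine as well, so a smaller fall in this assay is expected. The expected step is a 2.0-fold lower number from compound 1 to compound 3 (0.30 log units; within the scatter). For compound 3 the estimated value is 3100 nM, with a range of 1200 nM to 8000 nM.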

Compound 3, half-maximal inhibitory concentration: 12500 nM
Compound 3: middle estimate off by 4.0-fold (0.61 log units), on the low side, and the stated range ends below it.
By their numbers in this assay, from the lowest: compound 2; then compounds 1 and 3 (each within the scatter of the next).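

In this assay, hydrogen in place of methyl on the aromatic carbon ortho to a large group gives a 2.0-fold higher number from compound 1 to compound 3 (0.30 log units; within the scatter), so this methyl makes no difference that can be told from the scatter. The larger effect appears at the other substituent, where methyl in place of bromo gives an 8.0-fold higher number from compound 2 to compound 3 (0.90 log units; beyond the scatter), so the lower number of compound 2 goes with the bromo group, not with the missing methyl. Nothing available explains why bromo and methyl differ here.

Still open, as far as these compounds go, is whether chloro, methoxy or an amine in place of that bromo would match compound 2 or compound 3. The compounds shown also leave open how an unsubstituted phenyl would compare.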